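The source may hold more compounds than are shown below. What is called first, only, known or untested is meant among the compounds shown, and "the series" means these compounds.

Compound 3, `C[C@@H](NC(=O)Nc1ccc(F)cc1)c1ccccc1`, carries a single fluoro group on the aromatic ring attached to one nitrogen of the shared core. In an ADME assay on the whole organism with Oryza sativa as the target, tested at 10 uM (on this read-out lower numbers stand for a stronger effect and higher numbers for a weaker effect at the one concentration tested), compound 3 gives 92%, the highest of the three numbers measured. Compound 2, `C[C@@H](NC(=O)Nc1ccccc1F)c1ccccc1`, also carries one fluoro group on that ring, and in this assay compound 2 gives 77%. Compound 1, `CCCc1ccc(NC(=O)N[C@H](C)c2ccccc2)cc1`, carries a propyl group there instead, and in this assay compound 1 gives 35%.

Compound 4, `C[C@@H](NC(=O)Nc1ccc(F)cc1F)c1ccccc1`, differs from compound 3 by fluoro in place of hydrogen on an aromatic carbon. For the measured compounds named here, the one measured step that involves a fluoro group is a number 57 percentage points higher from compound 1 to compound 3 (beyond the scatter); that step swaps a whole propyl group for fluoro, whereas here a fluoro group merely takes the place of a hydrogen, so it hints at a direction but says little about size. Compound 2 and compound 3 each carry one fluoro group, and their two numbers show that a fluoro group alone can move the read-out by a moderate amount. A second fluoro group is therefore expected to shift the number only modestly, with the step of a number 7 percentage points lower from compound 3 to compound 4 (within the scatter) expected to be small. Compound 4 is estimated at 85%, with a range from 65% to 100%.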

Compound 4, a percentage reported as activity, at one concentration (the size of the read-out at that concentration, not a potency): 93%
The estimate for compound 4 lay 8 percentage points below the measured number; measured number inside the range.
By their numbers in this assay, from the lowest: compound 1; then compound 2; then compounds 3 and 4 (each within the scatter of the next).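

In this assay, a fluoro group in place of a hydrogen, ortho to a large group and meta to a fluoro group, gives a number 1 percentage points higher from compound 3 to compound 4 (within the scatter) and so leaves no readable change on compound 3. The same kind of swap made on compound 2 gives a number 16 percentage points higher from compound 2 to compound 4 (beyond the scatter) and does register, so among these compounds a second fluoro group matters on one parent and not on the other, which a single step could not have shown. No measurement shown here accounts for this contrast between the two parents.

On these data alone, it remains open whether the site ortho to a large group tolerates anything bigger than fluoro without a change in the number, as a chlorine atom, a methoxy group or a trifluoromethyl group there would test. As far as these compounds go, it is also open how far the read-out moves with other groups at the ring position that holds propyl in compound 1, such as a longer chain, an amine or a carboxylic acid.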